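Amine substituent step, compound 2 to compound 3

This account rests on a few compounds, and the source may have more. Where it says the series, first, only, none or still open, it means among the compounds named here.

- compound 1 `CNc1cc(Oc2c(OC)cc3cc(C#N)ccc3c2OC)nc(Nc2ccc(C#N)cc2)n1`: 239000 nM
- compound 2 `COc1cc2cc(C#N)ccc2c(OC)c1Oc1cc(NC2CCCCC2)nc(Nc2ccc(C#N)cc2)n1`: > 125000 nM, a limit
- compound 3 `COc1cc2cc(C#N)ccc2c(OC)c1Oc1cc(NCC2CCOCC2)nc(Nc2ccc(C#N)cc2)n1`: not yet measured

Both values come from an ADME assay on MT4 cells (Homo sapiens) for cytotoxicity, read by MTT assay, with a stated time of 5 days; on this read-out lower numbers stand for higher toxicity in this test and higher numbers for lower toxicity in this test. Compound 2 stands only at a limit, > 125000 nM. Compound 3 differs from it as follows: (oxan-4-yl)methyl in place of cyclohexyl on a nitrogen on an aromatic ring. Among the measured compounds shown here, the one measured step, a step that the limit leaves unreadable from compound 1 to compound 2, gives no size to carry over. With only compound 1 at 239000 nM as a number, no step beyond the scatter is expected in this assay. The expected size is a step that the limit leaves unreadable from compound 2 to compound 3. For compound 3 the estimate is 180000 nM, with an expected range of 80000 nM to 400000 nM.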

Compound 3, half-maximal cytotoxic concentration: > 125000 nM
Compound 3: only a limit was reported (the forecaster's own chance of this, stated with the estimate: 55%); the middle value is on the limit's open side.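

In this assay compound 3 gives > 125000 nM, a limit. No step from compound 1 or compound 2 to compound 3 can be read: the limit of > 125000 nM in this assay, at which 2 of the 3 values shown sit.

On these data alone, whether cyclohexyl and (oxan-4-yl)methyl on that nitrogen differ at all in cytotoxicity stays open.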